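From methyl to ethyl: compound 2 to compound 3

The compounds below may be only part of what the source reports. "The series", "measured", "known", "first", "only" and "open" are said of these compounds alone.

Values measured in an in vitro ADME assay on microsomes from liver (Homo sapiens) for pharmacokinetics (a lower number here means slower removal, a higher number faster removal of the compound), are as follows
- Compound 1 `Cc1ccc(S(=O)(=O)N2C=CNC(=O)[C@H]2CC(=O)NC2CCCCC2)cc1` gives 147 mL.min-1.g-1
- Compound 2 `Cc1ccc(S(=O)(=O)N2C=CNC(=O)[C@H]2CC(=O)N[C@H]2CCN(C)CC2(C)C)cc1` gives < 14 mL.min-1.g-1 as a limit of the assay, not a number

Compound 2 stands at the limit of < 14 mL.min-1.g-1 in this assay, at which 1 of the 2 values shown sits, and so has a limit here, not a number.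

Compound 3 `CCN1CC[C@H](NC(=O)C[C@@H]2C(=O)NC=CN2S(=O)(=O)c2ccc(C)cc2)C(C)(C)C1` differs from compound 2 by methyl in place of hydrogen on a saturated chain carbon bound to an amine nitrogen in a ring and this turns methyl to ethyl. For the measured compounds named here, no measured step tests a change of this kind. Going by the values given here, the one step with any bearing is an at least 10-fold lower number from compound 1 to compound 2 (1.02 log units; beyond the scatter) and it is large and beyond the scatter, but it exchanged the whole group on an amide-type nitrogen. The present change is much smaller. Compound 3 keeps the group that entered in an at least 10-fold lower number from compound 1 to compound 2 (1.02 log units; beyond the scatter), so it is expected to stay far closer to compound 2 than to compound 1 in this assay, with at most a small move toward faster removal. The estimated move is an at least 1.1-fold higher number from compound 2 to compound 3 (0.05 log units; that floor lies within the scatter) and it is expected to be small. For compound 3 the expected value is 16 mL.min-1.g-1, with an estimated range from 7 mL.min-1.g-1 to 40 mL.min-1.g-1.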

Compound 3, intrinsic clearance in microsomes: < 50 mL.min-1.g-1
Compound 3 was reported as a limit; the forecaster's own chance of this, stated with the estimate: 45%; the middle value does not contradict the limit.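

In this assay compound 3 is reported as a limit and not a number: the limit of < 50 mL.min-1.g-1 in this assay, at which 1 of the 3 values shown sits. The change of methyl to ethyl on the amine nitrogen in a ring cannot be read against compound 2 because compound 2 also has a limit and not a number: the limit of < 14 mL.min-1.g-1 in this assay, at which 1 of the 3 values shown sits. What the result adds is a comparison with the cyclohexyl amide, an at least 2.9-fold lower number from compound 1 to compound 3 (0.46 log units; beyond the scatter), which shows that the lower number in this assay seen on exchanging the whole group on the amide-type nitrogen is still beyond the scatter with ethyl on that ring nitrogen.

The compounds shown leave open how far, and even in which direction, ethyl moves the number in this assay relative to methyl, since neither compound has a measured number that would fix the size of that step. They also leave open whether a longer chain such as propyl, or a larger group such as benzyl, on the same amine nitrogen in a ring would keep the number in this assay lower than that of compound 1 by a margin beyond the scatter.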